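This account rests on a few compounds, and the source may have more. Where it says the series, first, only, none or still open, it means among the compounds named here.

Values in an ADME assay on cells (Hepatocyte, Mus musculus) for cytotoxicity, read by MTT assay, with a stated time of 24 h; a lower number here means that less compound is tolerated, a higher number that more compound is tolerated:

- compound 1 `FC(F)(F)c1ccc(-c2nn(-c3ccccc3)cc2-c2nc3ccccc3[nH]2)cc1`: 159000 nM
- compound 2 `Cc1ccc(C)c(S(=O)(=O)n2c(-c3cn(-c4ccccc4)nc3-c3ccc(F)cc3)nc3ccccc32)c1`: 122000 nM
- compound 3 `COc1ccc(S(=O)(=O)n2c(-c3cn(-c4ccccc4)nc3-c3ccc(C(F)(F)F)cc3)nc3ccccc32)cc1`: 87400 nM

Compound 3 lies within the scatter of both other compounds, so no order can be read among these numbers.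

The next compound is compound 4 `Cc1ccc(C)c(S(=O)(=O)n2c(-c3cn(-c4ccccc4)nc3-c3ccc(C(F)(F)F)cc3)nc3ccccc32)c1`, which has 2,5-dimethylphenyl in place of 4-methoxyphenyl on a sulfonyl sulfur.

Within the data shown here, the one measured step that bears on this change is a 1.8-fold lower number from compound 1 to compound 3 (0.26 log units; within the scatter). Even that step, which installs the whole sulfonyl group, stays within the scatter. No direct measurement of the exchange exists. Compound 2 carries the incoming (2,5-dimethylphenyl)sulfonyl group but differs from compound 4 elsewhere in the structure, and compound 2 gives 122000 nM.

Going by these compounds, no step beyond the scatter is therefore expected in this assay, and the direction remains open. The expected change is a 1.1-fold higher number from compound 3 to compound 4 (0.06 log units; within the scatter). For compound 4 the estimated value is 100000 nM, with an expected range of 55000 nM to 180000 nM.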

Compound 4, half-maximal cytotoxic concentration: 132000 nM
Compound 4: the middle estimate sits 1.3-fold (0.12 log units) below what was measured, and the stated range covers the measured number.
By their numbers in this assay, from the lowest: compounds 3, 2, 4 and 1 (each within the scatter of the next).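

In this assay the exchange of 4-methoxyphenyl for 2,5-dimethylphenyl on a sulfonyl sulfur now has a direct reading (a 1.5-fold higher number from compound 3 to compound 4 (0.18 log units; within the scatter)), and it shows that this position accepts the swap without a step beyond the scatter. Two further comparisons read the same way: trifluoromethyl in place of fluoro on an aromatic carbon (a 1.1-fold higher number from compound 2 to compound 4 (0.03 log units; within the scatter)) and (2,5-dimethylphenyl)sulfonyl in place of hydrogen on an aromatic nitrogen (a 1.2-fold lower number from compound 1 to compound 4 (0.08 log units; within the scatter)). No measurement at hand offers an explanation for these numbers.

Both sulfonyl aryl groups shown carry only methoxy or methyl substituents, so a basic amine or a carboxylic acid on that ring remains untested here. Going by these compounds, whether a longer alkyl chain in place of the aryl ring on the sulfonyl sulfur would leave the scatter also stays open.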